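Imidazoline for Amidine on a Longer Linker

The source may report more compounds than this note shows. Statements on the series, on what has been measured and on what is new or still open speak of the compounds shown alone.

Measured compounds:
compound 1, `CC(C)NC(=N)c1ccc2oc(-c3cccc(OCCCOc4ccccc4)c3)cc2c1`, 26500 nM
compound 2, `c1ccc(OCCCOc2cccc(-c3cc4cc(C5=NCCN5)ccc4o3)c2)cc1`, 6500 nM
compound 3, `CC(C)NC(=N)c1ccc2oc(-c3cccc(OCCCCCCOc4ccccc4)c3)cc2c1`, 7400 nM

All three were tested in an ADME assay on L6 cells (Rattus norvegicus) for cytotoxicity, read by resazurin assay, with a stated time of 70 h; on this read-out lower numbers stand for stronger inhibition and higher numbers for weaker inhibition. Compound 2 differs from compound 1 by a group of 5 heavy atoms (3 carbon, 2 nitrogen; one five-membered non-aromatic ring with 2 hetero atoms) in place of a group of 6 heavy atoms (4 carbon, 2 nitrogen; no ring), on an aromatic carbon, a change that gave a 4.1-fold lower number from compound 1 to compound 2 (0.61 log units; beyond the scatter). Compound 3 differs from compound 1 in the linker, by 3-phenoxypropyl in place of phenoxy on a saturated chain carbon, three bonds along the chain from an oxygen on an aromatic ring, which gave a 3.6-fold lower number from compound 1 to compound 3 (0.55 log units; beyond the scatter). Compound 4, `c1ccc(OCCCCCCOc2cccc(-c3cc4cc(C5=NCCN5)ccc4o3)c2)cc1`, has not yet been measured; it differs from compound 3 by a group of 5 heavy atoms (3 carbon, 2 nitrogen; one five-membered non-aromatic ring with 2 hetero atoms) in place of a group of 6 heavy atoms (4 carbon, 2 nitrogen; no ring), on an aromatic carbon, with the place described in the same words as for the pair of compound 1 and compound 2, so it is the same change carried onto the longer-linker core. If the change behaves as it did there, compound 4 is expected to show a 3.7-fold lower number from compound 3 to compound 4 (0.57 log units; beyond the scatter), resting on the single earlier step of a 4.1-fold lower number from compound 1 to compound 2 (0.61 log units; beyond the scatter). The estimate for compound 4 is therefore 2000 nM, with a likely range from 900 nM to 4500 nM.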

Compound 4, half-maximal inhibitory concentration: 2500 nM
Beside the measured number, compound 4's estimate is 1.3-fold (0.10 log units) below it; low and high end bracket the measured number.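

On the longer-linker core, imidazoline in place of the amidine gave a 3.0-fold lower number from compound 3 to compound 4 (0.47 log units; beyond the scatter) in this assay, and this step matches the one on the shorter-linker core: the same change on two cores in this assay, a 4.1-fold lower number (0.61 log units; beyond the scatter) from compound 1 to compound 2 and a 3.0-fold lower number (0.47 log units; beyond the scatter) from compound 3 to compound 4, 1.4-fold (0.14 log units) apart, within the scatter of two such steps

Lengthening the linker also carried over, giving a 2.6-fold lower number from compound 2 to compound 4 (0.41 log units; beyond the scatter): the same change on two cores in this assay, a 3.6-fold lower number (0.55 log units; beyond the scatter) from compound 1 to compound 3 and a 2.6-fold lower number (0.41 log units; beyond the scatter) from compound 2 to compound 4, 1.4-fold (0.14 log units) apart, within the scatter of two such steps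

Each change therefore kept a similar size on both of its cores, but this rests on four compounds and a single assay, so it does not show that either change would carry to other cores or why the numbers fall.

The compounds shown leave open whether a still longer chain would lower the number further. They also leave open how a primary amine in place of the amidine would behave.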